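The source may hold more compounds than are shown below. What is called first, only, known or untested is meant among the compounds shown, and "the series" means these compounds.

Working notes on the series. In a functional assay on K562 cells (Homo sapiens) for antiproliferative activity, read by trypan blue exclusion, with a stated time of 48 h, tested at 10 uM (on this read-out lower numbers stand for less inhibition of growth and higher numbers for more inhibition of growth at the one concentration tested), compound 1 (`Cc1ccc(NC(=O)/C=C/c2ccccc2)c(C(N)=O)c1`) gives 65.4% and compound 2 (`NC(=O)c1cc(Br)ccc1NC(=O)/C=C/c1ccccc1`) gives 62.4%. Compound 3 (`NC(=O)c1cc(Cl)ccc1NC(=O)/C=C/c1ccccc1Br`) gives 49%, the lowest of the three numbers and beyond the scatter from both of the others.

The next structure is compound 4 (`NC(=O)c1cc(Cl)ccc1NC(=O)/C=C/c1cccc(Br)c1`), which has the same atoms as compound 3, joined differently: 3-bromophenyl in place of 2-bromophenyl on a double-bonded chain carbon bound to a double-bonded chain carbon. The bromine therefore moves while the rest of the structure stays the same.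

Going by the values given here, the only measured step in a single place is a number 3 percentage points lower from compound 1 to compound 2 (within the scatter), with bromo in place of methyl on an aromatic carbon. Among the compounds with values here, that step concerns a different part of the structure and offers only indirect guidance, and no measured pair isolates the position of the bromine. A change within the scatter is therefore expected in this assay, with a slight upward lean, since compound 3 at 49% is the lowest so far. The estimated change is a number 4 percentage points higher from compound 3 to compound 4 (within the scatter). For compound 4, the estimated value is 53%, with an expected range of 38% to 68%.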

Compound 4, percent growth inhibition at one concentration: 27%
Beside the measured number, compound 4's estimate is 26 percentage points above it; the measured number lies below the stated range.
By their numbers in this assay, from the lowest: compound 4; then compound 3; then compounds 2 and 1 (each within the scatter of the next).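

In this assay, the exchange of 2-bromophenyl for 3-bromophenyl on a double-bonded chain carbon bound to a double-bonded chain carbon gives a number 22 percentage points lower from compound 3 to compound 4 (beyond the scatter). The leaving and entering groups have the same heavy atoms and the same counts of hydrogen-bond donors and acceptors, so this pair shows that the placing of the bromine alone goes with a difference beyond the scatter, which the earlier step, at another place and within the scatter, could not show. No measurement on hand explains the difference.

This single pair carries a chloro substituent on the shared core, so it leaves open whether the same difference appears with the methyl or bromo of compounds 1 and 2. It also leaves open how an amine or a carboxylic acid in place of the bromine would read in this assay.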